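The compounds below may be only part of what the source reports. "The series", "measured", "known", "first", "only" and "open" are said of these compounds alone.

In a functional assay, with a stated time of 30 min (on this read-out lower numbers stand for stronger inhibition and higher numbers for weaker inhibition), compound 3 `Oc1ccc(/C=N/n2c(S)nnc2-c2cnccn2)cc1` gives 58900 nM. Compound 1 `Oc1ccc2ccccc2c1/C=N/n1c(S)nnc1-c1cnccn1` gives 69200 nM and compound 2 `Oc1ccc(/C=N/n2c(S)nnc2-c2cnccn2)c(O)c1` gives 75900 nM, so all three numbers lie within the usual scatter of one another and compound 3 cannot be set apart from either. Compound 4 `Sc1nnc(-c2cnccn2)n1/N=C/c1ccccc1` differs from compound 3 by hydrogen in place of hydroxy on an aromatic carbon. For the measured compounds named here, one measured step bears on this change: a 1.3-fold lower number from compound 2 to compound 3 (0.11 log units; within the scatter), where a hydroxy group was likewise replaced by hydrogen, though elsewhere on the ring. That step stayed within the scatter, so the estimated step of a 1.0-fold higher number from compound 3 to compound 4 (0.01 log units; within the scatter) is expected to be no larger than the scatter itself, in no clear direction. Compound 4 is therefore expected to give 60000 nM, with a range from 25000 nM to 145000 nM.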

Compound 4, half-maximal inhibitory concentration: 52400 nM
Estimate against measurement, compound 4: 1.1-fold (0.06 log units) above; the measured number falls inside the stated range.
By their numbers in this assay, from the lowest: compounds 4, 3, 1 and 2 (each within the scatter of the next).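

In this assay, the change from 4-hydroxyphenyl to phenyl gives a 1.1-fold lower number from compound 3 to compound 4 (0.05 log units; within the scatter), so the hydroxy para to a large group can give way to hydrogen without a change beyond the scatter. Together with a 1.3-fold lower number from compound 2 to compound 3 (0.11 log units; within the scatter), this shows that neither replacement of hydroxy by hydrogen on this ring moves the number beyond the scatter. Nothing measured here offers an explanation for this result. On these data alone, whether an amine or a carboxylic acid in this place would shift the number beyond the scatter remains open.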